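The source may report more compounds than this note shows. Statements on the series, on what has been measured and on what is new or still open speak of the compounds shown alone.

Measured in a functional assay on NALM-6 cells (Homo sapiens) for cytotoxicity, with a stated time of 72 h; on this read-out lower numbers stand for an effect already at smaller amounts and higher numbers for an effect only at larger amounts of compound
- Compound 1 `C=C[C@@](C)(/C=C/c1ccc(O)cc1)CC/C=C(C)/C=N/N` gives > 43400 nM, a limit.
- Compound 2 `CCOC(=O)/C(C)=C/c1cc(/C=C/[C@](C)(/C=C/c2ccc(OC)cc2)CCC=C(C)C)ccc1O` gives > 43400 nM, a limit.
- Compound 3 `COc1ccc(/C=C/[C@@](C)(/C=C/c2ccc(O)c(/C=C/C(=O)OC(C)(C)C)c2)CCC=C(C)C)cc1` gives > 43400 nM, a limit.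

Compound 3 has a limit and no number, and the series offers no number either: the limit of > 43400 nM in this assay, at which 3 of the 3 values shown sit. Compound 4 `COc1ccc(/C=C/[C@@](C)(/C=C/c2ccc(O)cc2)CCC=C(C)C)cc1` carries hydrogen in place of 2-(tert-butoxycarbonyl)ethenyl on an aromatic carbon, ortho to a hydroxy group: hydrogen in place of 2-(tert-butoxycarbonyl)ethenyl on an aromatic carbon. For the measured compounds named here, the one measured step touching this group is a step that the two limits leave unreadable from compound 2 to compound 3, so it supplies no size. Compound 1 also lacks this group and gives > 43400 nM, a limit. No step beyond the scatter is therefore expected in this assay, and no direction can be argued. The expected change is an at least 1.0-fold lower number from compound 3 to compound 4 (0.03 log units; that floor lies within the scatter). For compound 4 the estimate is 40000 nM, with an expected range of 15000 nM to 60000 nM.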

Compound 4, half-maximal effective concentration: > 43400 nM
Compound 4 ended at the assay's limit; the forecaster's own chance of this, stated with the estimate: 70%; at least 1.0-fold (0.03 log units) between middle value and limit.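

Compound 4 gives > 43400 nM, a limit. The steps from compound 2 and compound 3 to compound 4 cannot be read, and the series stays at one value: the limit of > 43400 nM in this assay, at which 4 of the 4 values shown sit. The compounds shown leave open whether swapping the group on the aromatic carbon changes cytotoxicity at all.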